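A few compounds are considered here, and "the series" means these few. Any claim that something is new, unique, unknown or untested is made for them only; others in the source may bear on it.

Among the measured compounds shown here, in a functional assay on A549 cells (Homo sapiens) for cytotoxicity, read by MTT assay, with a stated time of 72 h (a lower number here means a stronger inhibitor, a higher number a weaker inhibitor), compound 3 (`COc1ccc(/C=C2\CCC/C(=C\c3ccc(Cl)cc3)C2=O)cc1OC`) gives 10100 nM, the only true number among the measured compounds. Compound 1 (`COc1cccc(/C=C2\CCC/C(=C\c3ccccc3Cl)C2=O)c1OC`) reports only a limit, > 20000 nM. Compound 2 (`COc1cccc(/C=C2\CCC/C(=C\c3ccc(Br)cc3)C2=O)c1OC`) also reports only a limit, > 20000 nM. The remaining measurements therefore rest on (the limit of > 20000 nM in this assay, at which 2 of the 3 values shown sit).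

Compound 4 (`COc1ccc(/C=C2\CCC/C(=C\c3ccc(OC)c(OC)c3)C2=O)cc1`) departs from compound 3 by one change: methoxy in place of chloro on an aromatic carbon. Methoxy takes the place of chloro on an aromatic carbon, para to a large group, turning 4-chlorophenyl into 4-methoxyphenyl.

For the measured compounds named here, only one measured step offers any comparison, a step that the two limits leave unreadable from compound 1 to compound 2, and it involves a different replacement and gives no size to carry over. With no measured guide to size or direction, the expectation stays close to compound 3 at 10100 nM. The expected change is a 1.2-fold higher number from compound 3 to compound 4 (0.07 log units; within the scatter), which is no shift beyond the scatter in this assay. Compound 4 is estimated at 12000 nM, with an expected range from 4500 nM to 20000 nM.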

Compound 4, half-maximal inhibitory concentration: > 20000 nM
Compound 4: a limit, no number; the forecaster's own chance of this, stated with the estimate: 30%; at least 1.6-fold (0.22 log units) between middle value and limit.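

Methoxy in place of chloro on this aromatic carbon, para to a large group, gives an at least 1.9-fold higher number from compound 3 to compound 4 (0.29 log units; that floor lies within the scatter) in this assay, so the step has a direction, though its floor does not establish a shift beyond the scatter. Compound 4 reports only a limit, > 20000 nM, so 4-methoxyphenyl shows no gain over 4-chlorophenyl here, and the true size of the step cannot be told. Among the compounds shown here, compound 3 remains the only compound with a true number, and the comparison otherwise rests on one limit: the limit of > 20000 nM in this assay, at which 3 of the 4 values shown sit.

From the compounds shown here alone, how far compound 4 lies past its limit stays open, and the step from compound 1 to compound 2 cannot be read. The compounds shown also leave open how an amine or a carboxylic acid in place of chloro at this position would read in this assay.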